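Aryl change between compound 3 and compound 4

The source may report more compounds than this note shows. Statements on the series, on what has been measured and on what is new or still open speak of the compounds shown alone.

In a physicochemical assay for permeability, using PAMPA (on this read-out higher numbers stand for higher permeability and lower numbers for lower permeability), compound 1 `Cc1ccc(C)c(-c2nc(CN3CCC(C(=O)NCCCN4C[C@H](C)C[C@H](C)C4)CC3)c(C)o2)c1` stands as "not determined" (no result reported), so it offers no guidance. In the same assay compound 2 `Cc1oc(-c2ccccc2Cl)nc1CN1CCC(C(=O)NCCCN2C[C@H](C)C[C@H](C)C2)CC1` gives 352 10^-6 cm/s. Compound 3 `Cc1oc(-c2c(Br)cccc2Br)nc1CN1CCC(C(=O)NCCCN2C[C@H](C)C[C@H](C)C2)CC1` reports only a limit, < 1 10^-6 cm/s, and not a number. The next structure is compound 4 `COc1cccc(Cl)c1-c1nc(CN2CCC(C(=O)NCCCN3C[C@H](C)C[C@H](C)C3)CC2)c(C)o1`, which differs in one place: 2-chloro-6-methoxyphenyl in place of 2,6-dibromophenyl on an aromatic carbon. The swap puts 2-chloro-6-methoxyphenyl in place of 2,6-dibromophenyl on an aromatic carbon. The entering group has the chlorine of the 2-chlorophenyl in compound 2 and also a second substituent, as the 2,6-dibromophenyl in compound 3 has. For the measured compounds named here, one measured step bears on this change, and it is large: an at least 350-fold lower number from compound 2 to compound 3 (2.54 log units; beyond the scatter). As compound 4 shares features with both neighbours, that single step suggests a value between them, though another limit remains possible. The expected change is an at least 15-fold higher number from compound 3 to compound 4 (1.17 log units; beyond the scatter), towards higher numbers in this assay. The estimated value for compound 4 is 15 10^-6 cm/s, with an expected range of 1.5 10^-6 cm/s to 150 10^-6 cm/s.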

Compound 4, apparent permeability: 51 10^-6 cm/s
The estimate for compound 4 lay 3.4-fold (0.53 log units) below the measured number; low and high end bracket the measured number.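

Compound 3 holds a limit and not a number: the limit of < 1 10^-6 cm/s in this assay, at which 1 of the 4 values shown sits.

In this assay, the 2,6-dibromophenyl result does not carry over to every aryl group with a second substituent at this position, as the data show an at least 51-fold higher number from compound 3 to compound 4 (1.70 log units; beyond the scatter). Compared with the 2-chlorophenyl parent, the added methoxy still costs something, with a 6.9-fold lower number from compound 2 to compound 4 (0.84 log units; beyond the scatter), so compound 4 sits on a measurable middle ground and the second substituent's identity matters here.

With three readable entries, the data leave open whether the low end reached by compound 3 goes with bromine itself or with having two halogens on the ring. A hydroxy group or an amine in place of the methoxy would test how far the number in this assay follows the group entering there.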